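A Third Fluorine on the Difluoromethyl Group

The source may hold more compounds than are shown below. What is called first, only, known or untested is meant among the compounds shown, and "the series" means these compounds.

In an ADME assay on cells for inhibition of cytochrome P450 11B1, mitochondrial (Homo sapiens), read by HPLC, with a stated time of 60 min (a lower number here means a stronger inhibitor, a higher number a weaker inhibitor), compound 3 `Fc1cc2nc(-c3cncnc3C(F)F)n(C3CC3)c2cc1F` gives 4330 nM. Compound 2 `CN(C)c1ncncc1-c1nc2cc(F)c(F)cc2n1C1CC1` gives 4630 nM and compound 1 `N#Cc1ncncc1-c1nc2cc(F)c(F)cc2n1C1CC1` gives 4990 nM, so all three stand within the scatter of one another. Compound 4 `Fc1cc2nc(-c3cncnc3C(F)(F)F)n(C3CC3)c2cc1F` differs from compound 3 by fluoro in place of hydrogen on a saturated chain carbon bound to an aromatic carbon and two fluorine atoms. Among the measured compounds shown here, the steps that bear on this all exchange the group on that aromatic carbon: a 1.2-fold lower number from compound 1 to compound 3 (0.06 log units; within the scatter), a 1.1-fold lower number from compound 2 to compound 3 (0.03 log units; within the scatter) and a 1.1-fold lower number from compound 1 to compound 2 (0.03 log units; within the scatter), none beyond the scatter. Since cyano, dimethylamino and difluoromethyl at this position give numbers within the scatter of each other, compound 4 is expected to show a 1.0-fold higher number from compound 3 to compound 4 (0.02 log units; within the scatter). The estimate for compound 4 is 4500 nM, with a range from 2200 nM to 9000 nM.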

Compound 4, half-maximal inhibitory concentration: 4770 nM
Beside the measured number, compound 4's estimate is 1.1-fold (0.03 log units) below it; measured number inside the range.
By their numbers in this assay, from the lowest: compounds 3, 2, 4 and 1 (each within the scatter of the next).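

In this assay the third fluorine brings only a 1.1-fold higher number from compound 3 to compound 4 (0.04 log units; within the scatter), so difluoromethyl to trifluoromethyl adds no step beyond the scatter at this position. Trifluoromethyl also stands level with the other two groups, with a 1.0-fold higher number from compound 2 to compound 4 (0.01 log units; within the scatter) and a 1.0-fold lower number from compound 1 to compound 4 (0.02 log units; within the scatter), which extends the flat picture to four groups on this aromatic carbon across compounds 1 to 4. Nothing shown accounts for this flatness.

Going by these compounds, whether any group here can move the number beyond the scatter stays open. A carboxylic acid, a primary amine or a longer chain on this carbon could answer that.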